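Benzyl Removal on the Phenyl Ketone: Expected Effect

The source may report more compounds than this note shows. Statements on the series, on what has been measured and on what is new or still open speak of the compounds shown alone.

Compound 2 `O=C(/C=C/c1ccc2c(c1)B(O)OC2)c1ccc(OCc2ccccc2)cc1` gives 12100 nM in a functional assay on HCT-116 cells (Homo sapiens) for cytotoxicity, read by MTT assay, with a stated time of 48 h (a lower number here means a stronger inhibitor, a higher number a weaker inhibitor), and the other measured compound, compound 1 `O=C(/C=C/c1ccc2c(c1)B(O)OC2)c1ccco1`, gives 24100 nM there, the two values lying within the usual scatter of each other. Compound 3 `O=C(/C=C/c1ccc2c(c1)B(O)OC2)c1ccc(O)cc1` differs from compound 2 by hydrogen in place of benzyl on an oxygen on an aromatic ring. For the measured compounds named here, no measured pair shows this change, so its size in this assay is open. Compound 3 is estimated at 18000 nM, within 6000 nM to 55000 nM, a step of a 1.5-fold higher number from compound 2 to compound 3 (0.17 log units; within the scatter) expected to stay within the scatter.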

Compound 3, half-maximal inhibitory concentration: 24100 nM
Compound 3: middle estimate off by 1.3-fold (0.13 log units), on the low side, within the range that was stated.
By their numbers in this assay, from the lowest: compounds 2, 1 and 3 (each within the scatter of the next).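

In this assay, hydrogen in place of benzyl on the oxygen gives a 2.0-fold higher number from compound 2 to compound 3 (0.30 log units; within the scatter) and so, unlike the earlier pair, reads this change directly: going from benzyloxy to hydroxy leaves the number within the scatter. 4-Hydroxyphenyl in place of furan-2-yl on the carbonyl carbon gives no change at the digits printed from compound 1 to compound 3 (within the scatter) and so adds no separation among these three compounds. No available evidence bears on why these steps are this small. As far as these compounds go, whether an amine or a carboxylic acid in place of the hydroxy would give a step beyond the scatter remains open, as does the effect of a simple ethyl chain on that oxygen.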